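A few compounds are considered here, and "the series" means these few. Any claim that something is new, unique, unknown or untested is made for them only; others in the source may bear on it.

Values in a functional assay on A-431 cells (Homo sapiens) for cytotoxicity (on this read-out lower numbers stand for an effect already at smaller amounts and higher numbers for an effect only at larger amounts of compound), so far

- compound 1 `COC1=C(C)C(=O)/C(=C(O)/C=C/c2ccc(OC)cc2)C(=O)C1(C)C` at 9.2 ug/mL
- compound 2 `COC1=C(C)C(=O)/C(=C(O)/C=C/c2ccc(C)cc2)C(=O)C1(C)C` at 5.1 ug/mL
- compound 3 `COC1=C(C)C(=O)/C(=C(O)/C=C/c2c(C)cc(C)cc2C)C(=O)C1(C)C` at 20 ug/mL

Compound 2 at 5.1 ug/mL lies within the scatter of compound 1 at 9.2 ug/mL and has a lower number than compound 3 at 20 ug/mL by more than the scatter. The next structure is compound 4 `COC1=C(C)C(=O)/C(=C(O)/C=C/c2cccs2)C(=O)C1(C)C` with thiophen-2-yl in place of 4-methylphenyl on a double-bonded chain carbon bound to a double-bonded chain carbon as its change from compound 2.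

For the measured compounds named here, the only measured step of a 1.8-fold lower number from compound 1 to compound 2 (0.26 log units; within the scatter) stays within the scatter and does not replace the whole group, so it bears on this change only weakly. Going by the values given here, compound 3 at 20 ug/mL shows that the number can move when this group differs, but no single-place step ties it to the others. Among the compounds with values here, no measured step puts a five-membered aromatic ring at this place. In this assay no step beyond the scatter is therefore expected. The expected step of a 1.4-fold higher number from compound 2 to compound 4 (0.14 log units; within the scatter) is only an estimate and stays within the scatter. Compound 4 is estimated at 7 ug/mL with an expected range from 2.5 ug/mL to 18 ug/mL for now.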

Compound 4, concentration for half-maximal effect: 10.8 ug/mL
Estimate against measurement, compound 4: 1.5-fold (0.19 log units) below; the measured number falls inside the stated range.
By their numbers in this assay, from the lowest: compounds 2, 1, 4 and 3 (each within the scatter of the next, the first and the last beyond it).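

Thiophen-2-yl is the first five-membered aromatic ring at this place, on a double-bonded chain carbon bound to a double-bonded chain carbon, and in this assay the replacement of 4-methylphenyl gives a modest step just past the usual scatter: a 2.1-fold higher number from compound 2 to compound 4 (0.33 log units; beyond the scatter). Against the 4-methoxyphenyl group the same ring gives no readable change: a 1.2-fold higher number from compound 1 to compound 4 (0.07 log units; within the scatter). The six-membered carbon ring is therefore not required for a number in this range, though nothing available explains the modest step from the 4-methylphenyl compound.

From the compounds shown here alone, whether other five-membered rings, such as furan-2-yl or thiazol-2-yl, behave like thiophen-2-yl remains open. Also open, going by these compounds, is how a dimethylamino group or a carboxylic acid on the aromatic ring at this place would shift the number.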